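Amino in place of chloro: one step seen, one awaited

A few compounds are considered here, and "the series" means these few. Any claim that something is new, unique, unknown or untested is made for them only; others in the source may bear on it.

Of the compounds shown here, three have been measured in a functional assay on OVCAR-5 cells (Homo sapiens) for cytotoxicity, read by sulforhodamine B assay, with a stated time of 48 h; on this read-out higher numbers stand for lower toxicity in this test and lower numbers for higher toxicity in this test. Compound 3 `ClCc1ccc(Cn2cnc3c(Cl)nc(Cl)nc32)cc1` gives 66100 nM. Compound 2 `ClCc1cccc(Cn2cnc3c(Cl)nc(Cl)nc32)c1` gives 47900 nM; these two numbers lie within the scatter of each other, and how their two cores differ is not broken down here. Compound 1 `Nc1nc(Cl)c2ncn(Cc3ccc(CCl)cc3)c2n1` is the amino counterpart of compound 3, and in this assay compound 1 reaches only the limit of the assay, > 100000 nM. The change from compound 3 to compound 1, (amino in place of chloro on an aromatic carbon), thus gives an at least 1.5-fold higher number from compound 3 to compound 1 (0.17 log units; that floor lies within the scatter), a floor that comes from the limit of > 100000 nM in this assay, at which 1 of the 3 values shown sits.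

Compound 4 `Nc1nc(Cl)c2ncn(Cc3cccc(CCl)c3)c2n1` is not yet measured. It stands to compound 2 as compound 1 stands to compound 3: the change is amino in place of chloro on an aromatic carbon, the same change at the same place. Since the earlier instance of this change gave only a floor, the step is expected to be a 2.1-fold higher number from compound 2 to compound 4 (0.32 log units; beyond the scatter), resting on the move of compound 3 to the limit in an at least 1.5-fold higher number from compound 3 to compound 1 (0.17 log units; that floor lies within the scatter). Compound 4 is estimated at 100000 nM, between 40000 nM and 300000 nM, with a real chance that only a limit is returned.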

Compound 4, concentration lethal to 50% of the cells: 57500 nM
For compound 4 the middle estimate is 1.7-fold (0.24 log units) above the measured one; measured number inside the range.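

In this assay, amino in place of chloro on an aromatic carbon gives a 1.2-fold higher number from compound 2 to compound 4 (0.08 log units; within the scatter), so on this core the change leaves the number within the scatter. Carried from one core to the other, the change gives no figure beyond the scatter on either, yet this does not establish that it behaves alike on both: the same change on two cores in this assay, an at least 1.5-fold higher number (0.17 log units; that floor lies within the scatter) from compound 3 to compound 1 and a 1.2-fold higher number (0.08 log units; within the scatter) from compound 2 to compound 4; the limit leaves it open whether they differ. Going by these compounds, the size of the earlier step remains unknown, and it could be larger than the later one, because only a floor is available for it: the limit of > 100000 nM in this assay, at which 1 of the 4 values shown sits.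

The compounds shown leave open whether another group in the same place, between two ring nitrogen atoms, such as a methylamino group, a methoxy group or a hydroxyl group, would give a step beyond the scatter in this assay. They also leave open whether the same change would read the same way if the chloro group meta to this place gave way to an amine or a longer chain.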